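Extending the Acyl Chain from Compound 3 to Compound 4

The source may hold more compounds than are shown below. What is called first, only, known or untested is meant among the compounds shown, and "the series" means these compounds.

Three amides on a shared core have been tested in an ADME assay on Vero cells (Chlorocebus sabaeus) for cytotoxicity; a lower number here means that less compound is tolerated, a higher number that more compound is tolerated. Compound 1 `CC(=O)Nc1nc(N)nc2c1ncn2[C@H]1CO[C@@H](CO)O1` gives > 100000 nM, which is a limit of the assay. Compound 2 `CCCCCCCC(=O)Nc1nc(N)nc2c1ncn2[C@H]1CO[C@@H](CO)O1` gives > 100000 nM, which is also a limit. Within the data shown here, compound 3 `CCCCCCCCCCCC(=O)Nc1nc(N)nc2c1ncn2[C@H]1CO[C@@H](CO)O1` gives 53000 nM, the only actual number in the set, so it has no measured neighbour to be ranked against.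

Compound 4 `CCCCCCCCCCCCCCCC(=O)Nc1nc(N)nc2c1ncn2[C@H]1CO[C@@H](CO)O1` has not yet been measured. Its structure departs from that of compound 3 by a single extension of the chain: butyl in place of hydrogen on a saturated chain carbon, ten or more bonds along the chain from a carbonyl carbon.

Among the measured compounds shown here, two measured steps bear on this change. The closest is an at least 1.8-fold lower number from compound 2 to compound 3 (0.27 log units; that floor lies within the scatter), where a butyl group also entered the chain. The other is an at least 1.8-fold lower number from compound 1 to compound 3 (0.27 log units; that floor lies within the scatter), made by a decyl group. Both are floors rather than sizes, and both point towards a lower number in this assay. The step that the two limits leave unreadable from compound 1 to compound 2 adds nothing readable.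

On the evidence of compound 3 and its step of an at least 1.8-fold lower number from compound 2 to compound 3 (0.27 log units; that floor lies within the scatter), a further small fall is expected, though not a large one. The expected change is a 1.7-fold lower number from compound 3 to compound 4 (0.22 log units; within the scatter). For compound 4 the estimated value is 32000 nM, within an expected range of 12000 nM to 90000 nM.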

Compound 4, half-maximal cytotoxic concentration: 90000 nM
Estimate against measurement, compound 4: 2.8-fold (0.45 log units) below, within the range that was stated.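

In this assay, the butyl extension gives a 1.7-fold higher number from compound 3 to compound 4 (0.23 log units; within the scatter), so the further fall suggested by the earlier floors does not appear and the two compounds cannot be told apart. The octyl change on a saturated chain carbon, seven bonds along the chain from a carbonyl carbon, reads as an at least 1.1-fold lower number from compound 2 to compound 4 (0.04 log units; that floor lies within the scatter), which is a floor rather than a size and also stays inside the usual scatter. With these two steps, the numbers give no trend with chain length past compound 3, and the comparisons with the shorter chains stay unsized because they rest on a limit: the limit of > 100000 nM in this assay, at which 2 of the 4 values shown sit.

The compounds shown leave open whether a longer chain than that of compound 4 would stay within the scatter of compound 3 and compound 4 or move clearly away from them. They also leave open how a carboxylic acid or an amine on this chain would read in this assay, as every acyl group here is a plain saturated chain.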